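Moving the bromine on the anilide ring of compound 3

The source may report more compounds than this note shows. Statements on the series, on what has been measured and on what is new or still open speak of the compounds shown alone.

The compounds measured so far, with their values in a physicochemical assay for lipophilicity, read by HPLC; a higher number here means a more lipophilic compound, a lower number a more polar compound:
compound 1, `COc1cccc(NC(=O)c2ccc3cccc(O)c3n2)c1`, gives 2.5;
compound 2, `Cc1ccc(NC(=O)c2ccc3cccc(O)c3n2)cc1`, gives 2.5;
compound 3, `O=C(Nc1ccccc1Br)c1ccc2cccc(O)c2n1`, gives 2.5.

Compound 3 stands level with compounds 1 and 2 in this assay, all three within the scatter of one another. Going by the values given here, the one single-point step among the measured compounds, no change at the digits printed from compound 2 to compound 3 (within the scatter), shows that exchanging the group on the amide-type nitrogen left the reading where it was.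

Compound 4, `O=C(Nc1cccc(Br)c1)c1ccc2cccc(O)c2n1`, differs from compound 3 in one place: 3-bromophenyl in place of 2-bromophenyl on an amide-type nitrogen. Among the compounds with values here, no measured step touches the position of the bromine on that ring, so the only bearing comes from the step from compound 2 to compound 3, which was flat. On that basis the step from compound 3 to compound 4 is expected to be small, a number 0.10 log units higher from compound 3 to compound 4 (within the scatter), with no change beyond the scatter in either direction. Compound 4 is therefore estimated to give 2.6 in this assay, within a range of 2.2 to 3.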

Compound 4, partition coefficient: 2.5
For compound 4 the middle estimate is 0.10 log units above the measured one; the range from low to high includes it.
By their numbers in this assay, from the lowest: compounds 1, 2, 3 and 4 (each within the scatter of the next).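

In this assay, going by these compounds alone, moving the bromine so that 3-bromophenyl stands in place of 2-bromophenyl on the amide-type nitrogen gives no change at the digits printed from compound 3 to compound 4 (within the scatter), the first reading on where the bromine sits on this ring. Compound 4 also matches the other two anilides, with no change at the digits printed from compound 2 to compound 4 (within the scatter) for 3-bromophenyl in place of 4-methylphenyl and no change at the digits printed from compound 1 to compound 4 (within the scatter) for bromo in place of methoxy on an aromatic carbon, so all four compounds read alike and none goes against that. No measurement shown here offers an explanation for this flat reading.

The compounds shown leave open whether the reading would hold with an amine or a carboxylic acid on this ring, or with a longer chain on the amide-type nitrogen. They also leave open whether the same flatness would appear in any other kind of assay.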